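A Fluorine Step Carried onto a Second Core

This account rests on a few compounds, and the source may have more. Where it says the series, first, only, none or still open, it means among the compounds named here.

Measured so far in a functional assay on HeLa cells (Homo sapiens) for inhibition, read by MTT assay, with a stated time of 48 h; on this read-out higher numbers stand for weaker inhibition of growth and lower numbers for stronger inhibition of growth:
compound 1 `Cn1cc(C2CC(c3ccccc3)=NN2C(=O)c2cccnc2)c2cc(Br)ccc21` gives 1730 nM
compound 2 `Cn1cc(C2CC(c3ccc(F)cc3)=NN2C(=O)c2cccnc2)c2cc(Br)ccc21` gives 630 nM
compound 3 `COc1ccc2c(c1)c(C1CC(c3ccccc3)=NN1C(=O)c1ccc(OC)nc1)cn2C` gives 1100 nM

Compound 1 and compound 2 share one core and differ only by fluoro in place of hydrogen on an aromatic carbon. That change made the step of a 2.7-fold lower number from compound 1 to compound 2 (0.44 log units; beyond the scatter), a modest gain in growth inhibition that is nonetheless larger than repeated measurements usually scatter. Compound 3 carries a different core; the difference between the two cores is not broken down here. Its value and that of compound 1 lie within the usual scatter of each other, so nothing can be said about their order.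

Compound 4 `COc1ccc2c(c1)c(C1CC(c3ccc(F)cc3)=NN1C(=O)c1ccc(OC)nc1)cn2C` is the unmeasured partner of compound 3, and it differs from compound 3 by fluoro in place of hydrogen on an aromatic carbon, the same change made from compound 1 to compound 2 at the same kind of place. Because the earlier step of a 2.7-fold lower number from compound 1 to compound 2 (0.44 log units; beyond the scatter) was beyond the scatter, a step of similar size is expected, a 2.4-fold lower number from compound 3 to compound 4 (0.39 log units; beyond the scatter). Compound 4 is therefore estimated to give 450 nM in this assay, most likely between 200 nM and 1100 nM.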

Compound 4, concentration for 50% growth inhibition: 410 nM
Beside the measured number, compound 4's estimate is 1.1-fold (0.04 log units) above it, within the range that was stated.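

In this assay, going from phenyl to 4-fluorophenyl on the second core gave a 2.7-fold lower number from compound 3 to compound 4 (0.43 log units; beyond the scatter), a modest gain in growth inhibition that is larger than repeated measurements usually scatter. Set beside the earlier step, the change carried over from one core to the other with its size intact: the same change on two cores in this assay, a 2.7-fold lower number (0.44 log units; beyond the scatter) from compound 1 to compound 2 and a 2.7-fold lower number (0.43 log units; beyond the scatter) from compound 3 to compound 4, 1.0-fold (0.01 log units) apart, within the scatter of two such steps. Within the data shown here, this shows only that the step held on these two cores in this one cell assay; it does not explain why fluoro gives this gain, and it does not promise the same step on any further core.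

The compounds shown leave open whether a chloro, methyl or trifluoromethyl group in that same place would give a step of similar size, since hydrogen and fluoro are the only two groups compared there. Also open, from the compounds shown here alone, is whether the step would hold on a third core or in a different cell line.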